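The compounds below may be only part of what the source reports. "The series", "measured", "known", "first", "only" and "open" are said of these compounds alone.

The set centres on three measured compounds sharing one core. Compound 1 `CC(C)n1nc(-c2cc(C3CCCCC3)on2)c2c(N)ncnc21` carries a cyclohexyl group, compound 2 `CC(C)n1nc(-c2ccon2)c2c(N)ncnc21` a hydrogen at the same position, and compound 3 `CC(C)n1nc(-c2cc(C(C)(C)C)on2)c2c(N)ncnc21` a tert-butyl group. In an assay on isolated protein for inhibition of proto-oncogene tyrosine-protein kinase receptor Ret (Homo sapiens), read by radiometric assay and 33P incorporation, in the presence of a further agent that is not named here (a higher number here means a weaker inhibitor, a lower number a stronger inhibitor), compound 1 gives 910 nM, compound 2 gives 213 nM, and compound 3 gives 210 nM. Among the measured compounds shown here, compound 3 has the lowest number of the three, but its value and that of compound 2 lie within the scatter of one another, as the step of a 1.0-fold lower number from compound 2 to compound 3 (0.01 log units; within the scatter) shows; only the step of a 4.3-fold lower number from compound 1 to compound 3 (0.64 log units; beyond the scatter) is beyond the scatter, as is the matching step a 4.3-fold lower number from compound 1 to compound 2 (0.63 log units; beyond the scatter). Compound 4 `CC(C)n1nc(-c2cc(-c3ccccc3)on2)c2c(N)ncnc21` is not yet measured; the change is phenyl in place of tert-butyl on an aromatic carbon. For the measured compounds named here, two measured steps bear on it: the step from hydrogen to tert-butyl, which changed nothing beyond the scatter, and the step from cyclohexyl to tert-butyl, where the six-membered ring carried the higher number. Since phenyl is likewise a six-membered ring, a modest rise in the number is expected for compound 4, about a 1.9-fold higher number from compound 3 to compound 4 (0.28 log units; within the scatter), with an estimate of 400 nM and a range from 130 nM to 1300 nM.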

Compound 4, half-maximal inhibitory concentration: 190 nM
For compound 4 the middle estimate is 2.1-fold (0.32 log units) above the measured one; the measured number falls inside the stated range.
By their numbers in this assay, from the lowest: compounds 4, 3 and 2 (each within the scatter of the next); then compound 1.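

In this assay, phenyl on this carbon next to the ring oxygen gives a number that cannot be told apart from that with tert-butyl (a 1.1-fold lower number from compound 3 to compound 4 (0.04 log units; within the scatter)) or with hydrogen (a 1.1-fold lower number from compound 2 to compound 4 (0.05 log units; within the scatter)). The six-membered ring as such therefore does not go with the higher number, since the aromatic phenyl and the saturated cyclohexyl differ beyond the scatter (a 4.8-fold lower number from compound 1 to compound 4 (0.68 log units; beyond the scatter)), and among these four compounds only cyclohexyl stands apart. Nothing available accounts for the difference between these two rings.

As far as these compounds go, it remains open whether a phenyl ring bearing a methoxy group or a carboxylic acid would keep the number at this level. An amine or a longer alkyl chain on the same carbon is equally untested by the compounds shown here.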